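The compounds below may be only part of what the source reports. "The series", "measured", "known", "first", "only" and "open" are said of these compounds alone.

Of the compounds shown here, three on the shared core have numbers so far in a functional assay on B16-F1 cells (Mus musculus) for antiproliferative activity, read by MTT assay, with a stated time of 72 h (on this read-out lower numbers stand for stronger inhibition and higher numbers for weaker inhibition), for this series. Compound 1 (`C/C=C1/[C@H](O[C@@H]2O[C@H](CO)[C@@H](O)[C@H](O)[C@H]2O)OC=C(C(=O)OC)[C@H]1CC(=O)OCCCCCCCCCCCCCCC`) reads 1500 nM and is the furthest from compound 2 (`C/C=C1/[C@H](O[C@@H]2O[C@H](CO)[C@@H](O)[C@H](O)[C@H]2O)OC=C(C(=O)OC)[C@H]1CC(=O)OCCc1ccc(O)c(O)c1`), which reads 284000 nM and stands highest of the three, the weakest inhibition seen here. Compound 3 (`C/C=C1/[C@H](O[C@@H]2O[C@H](COC(C)=O)[C@@H](OC(C)=O)[C@H](OC(C)=O)[C@H]2OC(C)=O)OC=C(C(=O)OC)[C@H]1CC(=O)OCCC`) is the nearest to it and reads 44000 nM in the same test.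

Compound 4 (`C/C=C1/[C@H](O[C@@H]2O[C@H](CO)[C@@H](O)[C@H](O)[C@H]2O)OC=C(C(=O)OC)[C@H]1CC(=O)OCCc1ccccc1`) carries phenyl in place of 3,4-dihydroxyphenyl on a saturated chain carbon, two bonds along the chain from an oxygen next to a carbonyl group. Among the measured compounds shown here, no measured pair isolates this change, so any expectation rests on the spread of the three numbers alone. With compound 2 at 284000 nM at the top of that spread, a moderate step toward lower numbers in this assay is expected, beyond the scatter. The estimated step is a 3.6-fold lower number from compound 2 to compound 4 (0.55 log units; beyond the scatter) on this evidence. For compound 4 the estimated value is 80000 nM (expected range 20000 nM to 300000 nM).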

Compound 4, half-maximal inhibitory concentration: 41000 nM
The estimate for compound 4 lay 2.0-fold (0.29 log units) above the measured number; low and high end bracket the measured number.
By their numbers in this assay, from the lowest: compound 1; then compounds 4 and 3 (each within the scatter of the next); then compound 2.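

In this assay, phenyl in place of 3,4-dihydroxyphenyl on a saturated chain carbon, two bonds along the chain from an oxygen next to a carbonyl group, gives a 6.9-fold lower number from compound 2 to compound 4 (0.84 log units; beyond the scatter), a modest step beyond the scatter. This is the first pair in the series that differs in one place, so this position is now shown to affect the read-out with the rest of the molecule held constant, and removing the two hydroxyl groups moves the number toward stronger inhibition. No measured information is available to explain this step.

A 3-hydroxyphenyl or 4-hydroxyphenyl group at this position would show whether the step follows one hydroxyl group or requires the loss of both. On these data alone, how a 3,4-dimethoxyphenyl or 4-aminophenyl group would read remains open.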